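A few compounds are considered here, and "the series" means these few. Any claim that something is new, unique, unknown or untested is made for them only; others in the source may bear on it.

The study measures cytotoxicity in a functional assay on HEL cells (Homo sapiens) for cytotoxicity; a higher number here means that more compound is tolerated, a lower number that less compound is tolerated. Compound 1 `C=CC[C@@H]1O[C@@H]2CO[C@@H](c3ccccc3)O[C@H]2[C@H](OC)[C@H]1OC` is recorded with "not determined" (no result reported) and so contributes no number. Compound 2 `O[C@@H]1[C@@H](O)[C@H](c2ccccc2)O[C@@H]2CO[C@@H](c3ccc(Cl)cc3)O[C@@H]12` reaches only a limit of the assay, >= 100 ug/mL. Compound 3 `CO[C@@H]1[C@@H](OC)[C@H](c2ccccc2)O[C@@H]2CO[C@@H](Cc3ccccc3)O[C@@H]12` stands at "not determined" (no result reported), so no number of its own exists for it. Among the three entries, one further value is a limit and one further entry gives no number, as shown by the limit of >= 100 ug/mL in this assay, at which 1 of the 3 values shown sits.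

Compound 4 `CO[C@@H]1[C@@H](OC)[C@H](c2ccccc2)O[C@@H]2CO[C@@H](c3ccc(Cl)cc3)O[C@@H]12` has not yet been measured in this assay. It differs from compound 3 in one place: 4-chlorophenyl in place of benzyl on a saturated ring carbon. Among the measured compounds shown here, no pair of measured compounds provides a step in this assay, so the size of the change from compound 3 to compound 4 cannot be read from measured values. The group that enters, 4-chlorophenyl, is the same group that compound 2 carries on its corresponding saturated ring carbon, and compound 2 gives only a limit in this assay. On that basis the step is expected to be none beyond the scatter, with the result most likely again reported as a limit rather than a number.

Compound 4 is therefore estimated in this assay to give 100 ug/mL, with a range from 50 ug/mL to 200 ug/mL.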

Compound 4, minimum cytotoxic concentration: >= 100 ug/mL
Compound 4: only a limit was reported (the forecaster's own chance of this, stated with the estimate: 75%); the middle value sits exactly at the limit.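

Among the compounds shown here, compound 4 reaches only a limit in this assay, >= 100 ug/mL, and compound 3 offers no number there, so no step from compound 3 to compound 4 can be read. The compounds shown leave open whether 4-chlorophenyl and benzyl differ at all in this read-out, and the values available stop here: the limit of >= 100 ug/mL in this assay, at which 2 of the 4 values shown sit.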